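The source may hold more compounds than are shown below. What is called first, only, known or untested is meant among the compounds shown, and "the series" means these compounds.

This account follows three compounds measured in an ADME assay on microsomes from liver (Rattus norvegicus) for metabolic stability, with a stated time of 60 min, tested at 1 uM (a higher number here means that more of the compound is left, a lower number that less of the compound is left), and a fourth compound that has not yet been measured. Compound 1 `COc1cn2ncc(-c3ccnc(OC(C)(C)C)c3)c2nc1-c1cnn(C)c1` gives 61% in this assay. Compound 3 `Cn1cc(-c2nc3c(-c4ccnc(OC5CC5)c4)cnn3cc2OCCCC(C)(C)O)cn1` gives 64% in this assay. Compound 2 `COc1cc(-c2cnn3cc(OC)c(C4CCCC4)nc23)ccn1` gives 7% in this assay, the lowest of the three numbers: the nearest number is that of compound 1, which stands higher by an amount beyond the usual scatter, and the furthest is that of compound 3, which also stands higher beyond the scatter.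

The unmeasured compound 4 `COc1cc(-c2cnn3cc(OC)c(C(C)(C)O)nc23)ccn1` differs from compound 2 in one place: 1-hydroxy-1-methylethyl in place of cyclopentyl on an aromatic carbon. Going by the values given here, no pair of measured compounds differs in only one place, so no measured step guides this change directly. What the numbers do show is that compound 1 at 61% and compound 3 at 64% both leave far more of the compound remaining than compound 2 does.

On that basis the step in this assay is expected to be upward and well beyond the scatter, a number 48 percentage points higher from compound 2 to compound 4 (beyond the scatter). Compound 4 is therefore expected to give about 55% in this assay, with an expected range from 30% to 80%.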

Compound 4, percent of the compound remaining: 92%
Estimate against measurement, compound 4: 37 percentage points below, and the stated range ends below it.
By their numbers in this assay, from the lowest: compound 2; then compounds 1 and 3 (each within the scatter of the next); then compound 4.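

On the shared core, the aromatic carbon next to the ring nitrogen and ortho to a methoxy group proves highly sensitive: in this assay, replacing cyclopentyl with 1-hydroxy-1-methylethyl gives a number 85 percentage points higher from compound 2 to compound 4 (beyond the scatter), a large step. Going by these compounds alone, this is the first reading of a change in one place, since the earlier compounds differ from one another in more than one place and could not tie any difference in the number to a single position. The data offer no measured explanation for the size of this step.

Within the data shown here, the single step also combines several differences, as the five-membered carbon ring leaves and an open group with an oxygen, a hydrogen-bond donor and a hydrogen-bond acceptor enters, so it cannot show which of them matters. As far as these compounds go, a tert-butyl group, a 1-amino-1-methylethyl group or a hydroxycyclopentyl group at this position would help separate them, and whether the step carries over to cores with other groups, such as the 1-methylpyrazole-bearing core of compound 1, remains open.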